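Cytotoxicity of Benzoxazole Piperazinyl Acetamides on Lung Cells

The source may report more compounds than this note shows. Statements on the series, on what has been measured and on what is new or still open speak of the compounds shown alone.

Measured compounds:
Compound 1, `CN(C)CCN1CCN(CC(=O)Nc2ccc(-c3nc4cc(F)ccc4o3)cc2)CC1`: 16600 nM
Compound 2, `Cc1ccc2oc(-c3ccc(NC(=O)CN4CCN(CCCN(C)C)CC4)c(C)c3)nc2c1`: 15300 nM

In a functional assay on A549 cells (Homo sapiens) for cytotoxicity, read by MTT assay, with a stated time of 24 h (on this read-out higher numbers stand for weaker inhibition and lower numbers for stronger inhibition), compound 2 gives 15300 nM and compound 1 gives 16600 nM; the two numbers sit within the scatter of each other, so neither stands apart. Compound 3, `Cc1ccc2oc(-c3ccc(NC(=O)CN4CCN(CCN(C)C)CC4)c(C)c3)nc2c1`, is not yet measured. It differs from compound 2 by dimethylamino in place of (dimethylamino)methyl on a saturated chain carbon, two bonds along the chain from an amine nitrogen in a ring: the 3-(dimethylamino)propyl chain of compound 2 reads as 2-(dimethylamino)ethyl in compound 3. Among the measured compounds shown here, no measured pair shows this change, so the step from compound 2 to compound 3 in this assay is expected to stay within the scatter, with no clear direction, as a 1.0-fold lower number from compound 2 to compound 3 (0.01 log units; within the scatter). Compound 3 is therefore estimated at 15000 nM, between 7000 nM and 32000 nM.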

Compound 3, half-maximal inhibitory concentration: 11000 nM
Compound 3: the middle estimate sits 1.4-fold (0.13 log units) above what was measured, and the stated range covers the measured number.
By their numbers in this assay, from the lowest: compounds 3, 2 and 1 (each within the scatter of the next).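

In this assay, the change from the 3-(dimethylamino)propyl chain to the 2-(dimethylamino)ethyl chain gives a 1.4-fold lower number from compound 2 to compound 3 (0.14 log units; within the scatter). Among the compounds shown here, this is the first single-place comparison available, and it shows that dimethylamino in place of (dimethylamino)methyl on this saturated chain carbon leaves the reading within the scatter. Nothing on hand offers a reason for this result.

The compounds shown leave open how a longer chain would read here. They also leave open whether a morpholine or a carboxylic acid at the chain end would move the number beyond the scatter.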